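Sulfonyl aryl exchange on the shared core toward compound 3

The source may hold more compounds than are shown below. What is called first, only, known or untested is meant among the compounds shown, and "the series" means these compounds.

Compound 2 `COc1ccc(-c2cc(=O)c3c(OC)cc(OC)cc3n2S(=O)(=O)c2ccc(F)cc2)cc1` is the starting point. In an ADME assay on BJ cells (Homo sapiens) for antiproliferative activity, with a stated time of 72 h (a lower number here means that less compound is needed, a higher number that more compound is needed for the effect), compound 2 reaches only a limit, > 65500 nM. Compound 1 `COc1ccc(-c2cc(=O)c3c(OC)cc(OC)cc3n2S(=O)(=O)c2cccc([N+](=O)[O-])c2)cc1` likewise gives only a limit in this assay, > 39600 nM. Among the measured compounds shown here, the single measured step, a step that the two limits leave unreadable from compound 1 to compound 2, is unreadable. The evidence on compound 1 is the limit of > 39600 nM in this assay, at which 1 of the 2 values shown sits. That on compound 2 is the limit of > 65500 nM in this assay, at which 1 of the 2 values shown sits. Compound 3 `COc1ccc(-c2cc(=O)c3c(OC)cc(OC)cc3n2S(=O)(=O)c2cc(Cl)cc(Cl)c2O)cc1` differs from compound 2 by 3,5-dichloro-2-hydroxyphenyl in place of 4-fluorophenyl on a sulfonyl sulfur. No readable step bears on this change, so no shift beyond the scatter is assumed; the expected step is an at least 1.3-fold lower number from compound 2 to compound 3 (0.11 log units; that floor lies within the scatter). Compound 3 is estimated at 50000 nM, within 12000 nM to 200000 nM.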

Compound 3, half-maximal effective concentration: > 37900 nM
Compound 3 ended at the assay's limit; the forecaster's own chance of this, stated with the estimate: 70%; the middle value does not contradict the limit.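

Compound 3 gives only a limit in this assay, > 37900 nM. Among the compounds shown here, compound 1 and compound 2 are also limits, so no step among the three can be read. Going by these compounds, whether any of these sulfonyl aryl groups gives a measurable value in this assay stays open.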